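Swapping the fluorinated benzoyl ring for a nitrophenyl one

This account rests on a few compounds, and the source may have more. Where it says the series, first, only, none or still open, it means among the compounds named here.

Compound 1, with the structure `CN(C(=O)NC(=O)c1c(F)cccc1F)c1nc(C(F)(F)F)c(C(=O)N/N=C/c2cccc(C(F)(F)F)c2)s1`, sits in the middle of three measured compounds. In a functional assay on BCG823 cells (Homo sapiens) for inhibition, read by MTT assay, with a stated time of 72 h (a higher number here means a weaker inhibitor, a lower number a stronger inhibitor), compound 1 gives 25.9 ug/mL. Among the measured compounds shown here, its nearest neighbour is compound 3, `Cc1nc(N(C)C(=O)NC(=O)c2c(F)cccc2F)sc1C(=O)N/N=C/c1cccc(C(F)(F)F)c1`, which in this assay gives 32.7 ug/mL; the only change, a 1.3-fold higher number from compound 1 to compound 3 (0.10 log units; within the scatter), is a step that stays within the scatter. Furthest away is compound 2, `CN(C(=O)NC(=O)c1ccc(F)c(F)c1)c1nc(C(F)(F)F)c(C(=O)N/N=C/c2ccccc2C(F)(F)F)s1`, which in this assay gives 3.66 ug/mL, a clearly lower number, but compound 2 differs from compound 1 in two places at once, so no single step can be read from it.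

Compound 4, `CN(C(=O)NC(=O)c1ccc([N+](=O)[O-])cc1)c1nc(C(F)(F)F)c(C(=O)N/N=C/c2cccc(C(F)(F)F)c2)s1`, is compound 1 with one change: 4-nitrophenyl in place of 2,6-difluorophenyl on a carbonyl carbon. For the measured compounds named here, no measured pair shows this change on its own. Going by the values given here, the one measured single step, from compound 1 to compound 3, touches a different part of the molecule and was within the scatter, so it says nothing about a nitrophenyl group. Among the compounds with values here, the two values of compound 1 and compound 2 show only that altering the benzoyl ring together with the hydrazone ring can lower the number.

With that thin basis, compound 4 is expected to give roughly 15 ug/mL in this assay, with a range from 4 ug/mL to 50 ug/mL, meaning an expected step of a 1.7-fold lower number from compound 1 to compound 4 (0.24 log units; within the scatter).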

Compound 4, half-maximal inhibitory concentration: 1.67 ug/mL
Beside the measured number, compound 4's estimate is 9.0-fold (0.95 log units) above it; the measured number lies below the stated range.
By their numbers in this assay, from the lowest: compound 4; then compound 2; then compounds 1 and 3 (each within the scatter of the next).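

In this assay, putting 4-nitrophenyl in place of 2,6-difluorophenyl on the carbonyl carbon gives a 16-fold lower number from compound 1 to compound 4 (1.19 log units; beyond the scatter) and marks this position as one where the number responds strongly. It is the first single change among these compounds to go beyond the scatter, whereas the swap of trifluoromethyl for methyl on the shared core gave a 1.3-fold higher number from compound 1 to compound 3 (0.10 log units; within the scatter) and stayed within it. Nothing measured here explains why the number falls so far.

On these data alone, this change removes both fluorines and adds a nitro group in one step, so it remains open whether the loss of fluorine, the arrival of the nitro group or the new place of the substituent on the ring carries the step. Also open, as far as these compounds go, is what a plain phenyl ring, a 4-aminophenyl group or a phenyl ring bearing a carboxylic acid would do on the same carbonyl carbon, and whether the lower number from 4-nitrophenyl holds when the core carries methyl instead of trifluoromethyl.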